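A few compounds are considered here, and "the series" means these few. Any claim that something is new, unique, unknown or untested is made for them only; others in the source may bear on it.

Of the compounds shown here, three sharing one core have been tested so far in an ADME assay on MRC5 cells (Homo sapiens) for inhibition, with a stated time of 72 h; on this read-out higher numbers stand for an effect only at larger amounts of compound and lower numbers for an effect already at smaller amounts. Compound 1 (`COc1cccc(OC)c1C(=O)Nc1c[nH]nc1C(=O)N[C@H]1CC[C@H](OC)CC1`) gives 31000 nM, compound 2 (`COc1cccc(OC)c1C(=O)Nc1c[nH]nc1C(=O)NCc1ccccc1`) gives 50000 nM, and compound 3 (`COc1cccc(OC)c1C(=O)Nc1c[nH]nc1C(=O)NC1CCC(C)CC1`) gives 45000 nM. Compound 3 therefore stands within the usual scatter of both other compounds, and the three cannot be ranked on these numbers. They differ only in the group on an amide-type nitrogen, and each swap was small: a 1.6-fold higher number from compound 1 to compound 2 (0.21 log units; within the scatter), a 1.5-fold higher number from compound 1 to compound 3 (0.16 log units; within the scatter) and a 1.1-fold lower number from compound 2 to compound 3 (0.05 log units; within the scatter).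

Compound 4 (`COC(=O)c1n[nH]cc1NC(=O)c1c(OC)cccc1OC`) carries methoxy in place of (4-methylcyclohexyl)amino on a carbonyl carbon. This change goes further than the measured swaps, since the amide-type nitrogen leaves along with its ring. Among the compounds with values here, no tested compound lacks that nitrogen, so the measured steps bear on this change only indirectly. They show a flat picture among the three tested groups, as in a 1.1-fold lower number from compound 2 to compound 3 (0.05 log units; within the scatter), and nothing yet points to a large move in either direction. The expected change is therefore none beyond the scatter, with an estimated 1.1-fold higher number from compound 3 to compound 4 (0.05 log units; within the scatter). Compound 4 is estimated at 50000 nM, with an expected range from 20000 nM to 100000 nM.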

Compound 4, half-maximal effective concentration: > 50000 nM
Compound 4: no number, only a limit; the forecaster's own chance of this, stated with the estimate: 40%; the middle value lies on the limit itself.
By their numbers in this assay, from the lowest: compounds 1, 3 and 2 (each within the scatter of the next).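

For compound 4 the read-out is a limit of the assay and not a number: the limit of > 50000 nM in this assay, at which 1 of the 4 values shown sits.

This is the first change shown that removes both the ring and the amide-type nitrogen, leaving methoxy on a carbonyl carbon, and in this assay it gives an at least 1.1-fold higher number from compound 3 to compound 4 (0.04 log units; that floor lies within the scatter), an at least 1.6-fold higher number from compound 1 to compound 4 (0.20 log units; that floor lies within the scatter) and a number no lower from compound 2 to compound 4 (the limit leaves the size open). On these data alone, that last step cannot be read, and the two readable steps are only floors, so the result shows no move towards an effect at smaller amounts, even with this much larger change, while the true size of any upward move stays unknown.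

The compounds shown leave open whether the amide-type nitrogen or its ring matters more, a question that a plain amino group on the same carbonyl carbon would help to separate. They also leave open how a carboxylic acid, or ethoxy as a longer chain in place of methoxy, would read out, and whether either would give a true number rather than a limit.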